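Oxan-2-yl Replacing Dimethylcarbamoylmethyl on the Pyrazole Nitrogen

The compounds below may be only part of what the source reports. "The series", "measured", "known", "first", "only" and "open" are said of these compounds alone.

Three compounds have been measured in an assay on isolated protein for inhibition of Discoidin domain-containing receptor 2 (Homo sapiens), read by ELISA, with a stated time of 60 min; on this read-out higher numbers stand for weaker inhibition and lower numbers for stronger inhibition:
compound 1 `Cc1ccc(C(=O)Nc2cccc(C(F)(F)F)c2)cc1-c1ccc2c(-c3cnn(C)c3)n[nH]c2c1` gives 4.4 nM;
compound 2 `Cc1ccc(C(=O)Nc2cccc(C(F)(F)F)c2)cc1-c1ccc2c(-c3cnn(C4CC4)c3)n[nH]c2c1` gives 3.2 nM;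
compound 3 `Cc1ccc(C(=O)Nc2cccc(C(F)(F)F)c2)cc1-c1ccc2c(-c3cnn(CC(=O)N(C)C)c3)n[nH]c2c1` gives 2.7 nM.

Compound 3 holds the lowest number of the three, yet its gaps to the others, a 1.2-fold lower number from compound 2 to compound 3 (0.07 log units; within the scatter) and a 1.6-fold lower number from compound 1 to compound 3 (0.21 log units; within the scatter), sit within the scatter, so the three cannot be ordered. Compound 4 `Cc1ccc(C(=O)Nc2cccc(C(F)(F)F)c2)cc1-c1ccc2c(-c3cnn(C4CCCCO4)c3)n[nH]c2c1` differs from compound 3 in one place: oxan-2-yl in place of (dimethylcarbamoyl)methyl on an aromatic nitrogen. Every measured step concerns this same aromatic nitrogen: a 1.4-fold lower number from compound 1 to compound 2 (0.14 log units; within the scatter), a 1.6-fold lower number from compound 1 to compound 3 (0.21 log units; within the scatter) and a 1.2-fold lower number from compound 2 to compound 3 (0.07 log units; within the scatter), all within the scatter. On that basis no step beyond the scatter is expected for compound 4, a 1.3-fold higher number from compound 3 to compound 4 (0.11 log units; within the scatter). Compound 4 is estimated at 3.5 nM, with a range from 1.5 nM to 9 nM.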

Compound 4, half-maximal inhibitory concentration: 5.2 nM
Compound 4: the middle estimate sits 1.5-fold (0.17 log units) below what was measured; measured number inside the range.
By their numbers in this assay, from the lowest: compounds 3, 2, 1 and 4 (each within the scatter of the next).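

Oxan-2-yl puts a six-membered non-aromatic ring, absent from the earlier compounds, on this aromatic nitrogen, and in this assay the steps stay inside the scatter: a 1.9-fold higher number from compound 3 to compound 4 (0.28 log units; within the scatter) and a 1.6-fold higher number from compound 2 to compound 4 (0.21 log units; within the scatter) and a 1.2-fold higher number from compound 1 to compound 4 (0.07 log units; within the scatter) all leave the number close to the others. Methyl, cyclopropyl, (dimethylcarbamoyl)methyl and oxan-2-yl therefore cannot be ordered on this read-out. Nothing available explains these numbers. Going by these compounds, whether an amine or a carboxylic acid on a longer chain at this nitrogen would give a step beyond the scatter stays open.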